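Swapping the carbamate tail for a trifluoromethylpyridinyl ether

This account rests on a few compounds, and the source may have more. Where it says the series, first, only, none or still open, it means among the compounds named here.

Measured so far:
- compound 1 `COc1nc(C)c(Nc2nc(Cl)cn([C@H](COC(=O)c3ccccc3)C3CC3)c2=O)cc1C`: 1.5 nM
- compound 2 `COc1nc(C)c(Nc2nc(Cl)cn([C@H](COC(=O)Nc3ccccc3)C3CC3)c2=O)cc1C`: 1.5 nM
- compound 3 `COc1nc(C)c(Nc2nc(Cl)cn([C@H](COC(=O)Nc3ccc(Cl)cc3)C3CC3)c2=O)cc1C`: 1.6 nM

All three values come from an assay on frontal cortex for displacement of a labelled ligand from corticotropin-releasing factor receptor 1 (Rattus norvegicus), with a stated time of 2 h; on this read-out higher numbers stand for weaker inhibition and lower numbers for stronger inhibition. Compound 3 gives the highest of the three numbers, yet its steps to the others are small: a 1.1-fold higher number from compound 1 to compound 3 (0.03 log units; within the scatter) and a 1.1-fold higher number from compound 2 to compound 3 (0.03 log units; within the scatter), both within the scatter, as is no change at the digits printed from compound 1 to compound 2 (within the scatter). Compound 4 `COc1nc(C)c(Nc2nc(Cl)cn([C@H](COc3ccc(C(F)(F)F)cn3)C3CC3)c2=O)cc1C` differs from compound 3 by 5-(trifluoromethyl)pyridin-2-yl in place of (4-chlorophenyl)carbamoyl on an oxygen on a saturated carbon. Within the data shown here, no measured step exchanges a carbamoyl for an aryl directly on that oxygen, so no step bears on it closely; the three small steps only show that changes at this end of the molecule have left this assay unmoved. Compound 4 is therefore expected to stay near compound 3, with a 1.9-fold higher number from compound 3 to compound 4 (0.27 log units; within the scatter) allowing a modest loss, an estimate of 3 nM within 0.8 nM to 12 nM.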

Compound 4, half-maximal inhibitory concentration: 1.6 nM
For compound 4 the middle estimate is 1.9-fold (0.27 log units) above the measured one, within the range that was stated.
By their numbers in this assay, from the lowest: compounds 1, 2, 3 and 4 (each within the scatter of the next).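

In this assay, placing 5-(trifluoromethyl)pyridin-2-yl on this oxygen gives no change at the digits printed from compound 3 to compound 4 (within the scatter), a 1.1-fold higher number from compound 2 to compound 4 (0.03 log units; within the scatter) and a 1.1-fold higher number from compound 1 to compound 4 (0.03 log units; within the scatter). So the carbonyl that compounds 1, 2 and 3 all carry on this oxygen is not required to keep the number at this level, and an aromatic ring can sit directly on the oxygen instead. Nothing shown explains why this position accepts such different groups. Still open, as far as these compounds go, is whether a free hydroxyl or a methyl ether on this carbon would hold the number, and whether a plain phenyl ether, without the trifluoromethyl and the ring nitrogen, would do the same.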